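Oxindole hydrazone series: halogen swap on the thiophene analogue

A few compounds are considered here, and "the series" means these few. Any claim that something is new, unique, unknown or untested is made for them only; others in the source may bear on it.

The series rests on compound 1 `O=C1Nc2ccc(Cl)cc2/C1=N/N=C/c1ccco1`, which in a functional assay on MCF7 cells (Homo sapiens) for cytotoxicity, read by sulforhodamine B assay, with a stated time of 48 h (a higher number here means a weaker inhibitor, a lower number a stronger inhibitor), gives 7750 nM. Compound 2 `O=C1Nc2ccc(F)cc2/C1=N/N=C/c1ccco1` carries the change fluoro in place of chloro on an aromatic carbon and gives 20300 nM, so that a 2.6-fold higher number from compound 1 to compound 2 (0.42 log units; beyond the scatter). Compound 3 `O=C1Nc2ccc(Cl)cc2/C1=N/N=C/c1cccs1` differs from compound 1 by thiophen-2-yl in place of furan-2-yl on a carbon with a double bond to nitrogen. In this assay compound 3 gives 15300 nM, and a 2.0-fold higher number from compound 1 to compound 3 (0.30 log units; within the scatter). Among the three measured numbers, compound 3 and compound 2 sit within the scatter of each other.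

Compound 4 `O=C1Nc2ccc(F)cc2/C1=N/N=C/c1cccs1` is not yet measured in this assay. It differs from compound 3 by fluoro in place of chloro on an aromatic carbon, which is the same change already seen between compound 1 and compound 2, with the place described in identical words. The two cores on which it is made differ by thiophen-2-yl in place of furan-2-yl on a carbon with a double bond to nitrogen.

The step from compound 3 to compound 4 is expected to resemble the earlier one, a 2.6-fold higher number from compound 3 to compound 4 (0.42 log units; beyond the scatter), because the same change gave a 2.6-fold higher number from compound 1 to compound 2 (0.42 log units; beyond the scatter) and the core difference a 2.0-fold higher number from compound 1 to compound 3 (0.30 log units; within the scatter) is small. Going by the values given here, compound 4 is therefore expected to give about 40000 nM in this assay, with a likely range of 20000 nM to 80000 nM; only two compounds support the transfer.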

Compound 4, half-maximal inhibitory concentration: 25800 nM
Compound 4: the middle estimate sits 1.6-fold (0.19 log units) above what was measured; low and high end bracket the measured number.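

On the thiophen-2-yl core, fluoro in place of chloro on an aromatic carbon gives a 1.7-fold higher number from compound 3 to compound 4 (0.23 log units; within the scatter) in this assay, and this step cannot be told apart from the one on the furan-2-yl core: the same change on two cores in this assay, a 2.6-fold higher number (0.42 log units; beyond the scatter) from compound 1 to compound 2 and a 1.7-fold higher number (0.23 log units; within the scatter) from compound 3 to compound 4, 1.6-fold (0.19 log units) apart, within the scatter of two such steps. Read the other way, thiophen-2-yl in place of furan-2-yl gives a 1.3-fold higher number from compound 2 to compound 4 (0.10 log units; within the scatter) on the fluoro compounds, which also agrees with the same swap on the chloro compounds: the same change on two cores in this assay, a 2.0-fold higher number (0.30 log units; within the scatter) from compound 1 to compound 3 and a 1.3-fold higher number (0.10 log units; within the scatter) from compound 2 to compound 4, 1.6-fold (0.19 log units) apart, within the scatter of two such steps. The change therefore carries across these two cores within the scatter, but this rests on four compounds only, and the step on the thiophen-2-yl core itself lies within the scatter, so the result does not show a reliable difference between compound 3 and compound 4 or any transfer to a further core.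

As far as these compounds go, it remains open whether bromo, methoxy, an amine or a carboxylic acid on the same aromatic carbon would behave alike on both cores. From the compounds shown here alone, whether any such step holds in other cell lines also remains open.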